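A few compounds are considered here, and "the series" means these few. Any claim that something is new, unique, unknown or untested is made for them only; others in the source may bear on it.

Series notes, step from compound 2 to compound 3.

Two members of the series have been measured in an assay on HEK293 cells for inhibition of Voltage-dependent T-type calcium channel subunit alpha-1G (Homo sapiens), read by fluorescence, tested at 10 uM; on this read-out lower numbers stand for less inhibition and higher numbers for more inhibition at the one concentration tested (going by the name of the read-out). Compound 1 `CCCc1nc(-c2ccccc2)c(CNCCCN2CCN(c3ccc(F)cc3)CC2)o1` gives 62.5%. Compound 2 `CCCc1nc(-c2ccccc2)c(CNCCCN2CCN(c3cccc(Cl)c3)CC2)o1` gives 65.9%. Within the data shown here, compound 2 and compound 1 lie within the scatter of each other, so the two numbers cannot be ranked; the only step available reads a number 3.4 percentage points higher from compound 1 to compound 2 (within the scatter).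

Compound 3 `CCCc1nc(-c2ccccc2)c(CNCCCN2CCN(c3cccc(C)c3C)CC2)o1` is the next compound to be measured in this assay. Its structure differs from compound 2 in one place:

2,3-dimethylphenyl in place of 3-chlorophenyl on an amine nitrogen in a ring

Among the measured compounds shown here, the single measured step, a number 3.4 percentage points higher from compound 1 to compound 2 (within the scatter), concerns the same position, an exchange of the aryl group on the ring nitrogen, and it stayed within the scatter. For the measured compounds named here, nothing measured so far speaks to a methyl-bearing aryl group at that position, so the expectation rests on that one step alone. On that basis no step beyond the scatter is expected for compound 3 in this assay; the estimated step is a number 1.9 percentage points lower from compound 2 to compound 3 (within the scatter). Compound 3 is therefore estimated at 64%, with a range from 46% to 80%.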

Compound 3, a percentage reported as inhibition, at one concentration (the size of the read-out at that concentration, not a potency): 55.2%
Compound 3: the middle estimate sits 8.8 percentage points above what was measured; the measured number falls inside the stated range.
By their numbers in this assay, from the lowest: compounds 3, 1 and 2 (each within the scatter of the next, the first and the last beyond it).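

Among these compounds, exchanging the aryl group on the ring nitrogen now gives a first step beyond the scatter in this assay: replacing 3-chlorophenyl with 2,3-dimethylphenyl gives a number 10.7 percentage points lower from compound 2 to compound 3 (beyond the scatter), so this position is not indifferent to the group it carries, although the step is modest. Against 4-fluorophenyl, the same 2,3-dimethylphenyl group gives a number 7.3 percentage points lower from compound 1 to compound 3 (within the scatter), so the separation holds only against compound 2, and compound 3 cannot be ranked against compound 1. No supporting evidence bears on this result, and the step remains unassigned to any cause.

The step from compound 2 to compound 3 removes a chlorine and brings in two methyl groups at once, so the compounds shown cannot separate these parts of the change. A phenyl ring bearing a single methyl, an unsubstituted phenyl or a pyridyl group on the same ring nitrogen would show whether the lower number belongs to the methyl pair or to the loss of the chlorine.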